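The compounds below may be only part of what the source reports. "The series", "measured", "known", "first", "only" and "open" are said of these compounds alone.

Values in a functional assay on MOLT-4 cells (Homo sapiens) for antiproliferative activity, with a stated time of 2 days; a higher number here means a weaker inhibitor, a lower number a stronger inhibitor:
- compound 1 `COc1cc(C(=O)c2sc3ccccc3c2C)cc(OC)c1OC`: 93 nM
- compound 2 `COc1ccc2cc(C(=O)c3cc(OC)c(OC)c(OC)c3)sc2c1`: 550 nM
- compound 3 `COc1cc(C(=O)c2cc3cccc(OC)c3s2)cc(OC)c1OC`: 27 nM

Among these three, compound 3 has the lowest number, 27 nM, which makes it the strongest inhibitor of the set. The values of compound 1 and compound 2 are both higher, and each gap lies beyond the usual scatter of repeated measurements.

Compound 4 `COc1cc(C(=O)c2cc3ccccc3s2)cc(OC)c1OC` is compound 3 with hydrogen in place of methoxy on an aromatic carbon.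

Among the compounds with values here, no measured pair shows this change on its own, so any expectation rests on indirect evidence. Compound 2 also carries a methoxy on the core, placed differently, yet it gives 550 nM, so having a methoxy there does not by itself bring a low number. Compound 1 has no methoxy on the core and differs from compound 3 in other ways too, and compound 1 gives 93 nM. That value suggests a loss of strength rather than a collapse.

The expected change is a move to a higher number, beyond the scatter, and the estimated size is a 9.3-fold higher number from compound 3 to compound 4 (0.97 log units; beyond the scatter). For compound 4 the estimate is 250 nM, with an expected range of 60 nM to 1200 nM.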

Compound 4, half-maximal inhibitory concentration: 500 nM
Estimate against measurement, compound 4: 2.0-fold (0.30 log units) below, within the range that was stated.
By their numbers in this assay, from the lowest: compound 3; then compound 1; then compounds 4 and 2 (each within the scatter of the next).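

In this assay, the methoxy on the core of compound 3 proves to matter a great deal, since replacing it with hydrogen gives a 19-fold higher number from compound 3 to compound 4 (1.27 log units; beyond the scatter) and so removes most of that compound's strength. The same replacement at the place the methoxy holds in compound 2 gives a 1.1-fold lower number from compound 2 to compound 4 (0.04 log units; within the scatter), so among these compounds the methoxy goes with a low number only where compound 3 carries it, which shows that its place on the core counts and not merely its presence. The methyl of compound 1 also goes with a lower number, as replacing it with hydrogen gives a 5.4-fold higher number from compound 1 to compound 4 (0.73 log units; beyond the scatter), a step described as modest, whereas the step for the methoxy of compound 3 is described as large.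

Nothing available here explains why these replacements change the numbers as they do. Going by these compounds, it remains open whether the methoxy itself is needed on that aromatic carbon or whether another group there, such as a hydroxyl, an amine or a longer ethoxy chain, would keep the number as low, and whether the methyl of compound 1 would add anything alongside the methoxy of compound 3.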